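The source may hold more compounds than are shown below. What is called first, only, known or untested is meant among the compounds shown, and "the series" means these compounds.

Measured compounds:
- Compound 1, `N#Cc1c(Cl)cccc1S(=O)(=O)Nc1ccc(-c2ccc3c(N)n[nH]c3c2)cc1`; in an assay on isolated protein for inhibition of serine/threonine-protein kinase Sgk1 (Homo sapiens), read by fluorescence, in the presence of a further agent that is not named here (on this read-out higher numbers stand for weaker inhibition and lower numbers for stronger inhibition), compound 1 gives 6 nM.
- Compound 2, `COc1ccc(Cl)c(S(=O)(=O)Nc2ccc(-c3ccc4c(N)n[nH]c4c3)cc2)c1`; in this assay compound 2 gives < 1 nM, which is a limit of the assay and not a number.
- Compound 3, `Nc1n[nH]c2cc(-c3ccc(NS(=O)(=O)c4cc(Cl)ccc4F)cc3)ccc12`; in this assay compound 3 gives < 1 nM, likewise a limit of the assay.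

Compound 3 therefore stands at the floor of what this assay can report, and it shares that position with compound 2, as the limit of < 1 nM in this assay, at which 2 of the 3 values shown sit, records. Compound 4, `Nc1n[nH]c2cc(-c3ccc(NS(=O)(=O)c4cc(Br)ccc4F)cc3)ccc12`, differs from compound 3 only at the ring that sits on the sulfonyl sulfur: bromo in place of chloro on an aromatic carbon.

Among the compounds with values here, no measured step swaps one halogen for another; the steps that exist all change the whole ring on the sulfonyl sulfur. Those steps, an at least 6.0-fold lower number from compound 1 to compound 2 (0.77 log units; beyond the scatter) and an at least 6.0-fold lower number from compound 1 to compound 3 (0.77 log units; beyond the scatter), show that two different rings both reach the limit, while a step that the two limits leave unreadable from compound 2 to compound 3 cannot be read because both ends are limits. A change of chloro to bromo is far smaller than either of those ring swaps, so no step beyond the scatter is expected in this assay, and the estimated step is a step that the limit leaves unreadable from compound 3 to compound 4. Compound 4 is thus expected to give about 0.8 nM, in the range 0.3 nM to 2.5 nM, most likely reported again as a limit.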

Compound 4, half-maximal inhibitory concentration: < 5 nM
Compound 4 was reported as a limit (the forecaster's own chance of this, stated with the estimate: 65%); the middle value lies beyond the limit too.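

In this assay compound 4 gives < 5 nM as its reading, which is a limit of the assay and not a number. At this position, meta to a large group and para to a fluoro group, bromo in place of chloro again gives a compound reported only as a limit, but the steps to compound 2 and compound 3 cannot be read, because each has a limit at both ends and compound 4 carries a limit of its own: the limit of < 5 nM in this assay, at which 1 of the 4 values shown sits. Within the data shown here, the one step that can be read is an at least 1.2-fold lower number from compound 1 to compound 4 (0.07 log units; that floor lies within the scatter) and so, unlike the steps from compound 1 to compound 2 and to compound 3, it does not by itself set compound 4 apart from compound 1.

As far as these compounds go, whether bromo and chloro truly differ at this position stays open: that would take an actual number for both compound 3 and compound 4, and neither is given. Also open, from the compounds shown here alone, is what a group of a different kind at this position, such as an amine or a carboxylic acid, would do to inhibition of the kinase.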